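A few compounds are considered here, and "the series" means these few. Any claim that something is new, unique, unknown or untested is made for them only; others in the source may bear on it.

For the measured compounds named here, compound 3 `COc1ncnc2c1c(-c1cc3ccccc3o1)cn2[C@@H]1O[C@H](CO)[C@@H](O)[C@H]1O` is the one compound here with a numbered result: in a functional assay on HL-60 cells (Homo sapiens) for antiproliferative activity, read by XTT assay, with a stated time of 72 h (on this read-out higher numbers stand for weaker inhibition and lower numbers for stronger inhibition), compound 3 gives 4470 nM. Compound 1 `CNc1ncnc2c1c(I)cn2[C@@H]1O[C@H](CO)[C@@H](O)[C@H]1O` stops at a limit of the assay, giving > 20000 nM in this assay. Compound 2 `CN(C)c1ncnc2c1c(-c1cc3ccccc3o1)cn2[C@@H]1O[C@H](CO)[C@@H](O)[C@H]1O` likewise stops at a limit, giving > 20000 nM in this assay. Going by the values given here, the single measured step is an at least 4.4-fold lower number from compound 2 to compound 3 (0.65 log units; beyond the scatter), methoxy in place of dimethylamino on an aromatic carbon; its size can only be given as a bound, since compound 2 rests at the limit of > 20000 nM in this assay, at which 2 of the 3 values shown sit.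

Compound 4 `CNc1ncnc2c1c(-c1cc3ccccc3o1)cn2[C@@H]1O[C@H](CO)[C@@H](O)[C@H]1O` differs from compound 3 by methylamino in place of methoxy on an aromatic carbon. This change touches the same aromatic carbon as the measured step, but methylamino is a different group from dimethylamino, so that step does not directly tell what to expect. Compound 1 also carries methylamino, yet it differs from compound 4 elsewhere as well, and its limit value alone cannot settle the matter. With only these numbers in hand, a step within the scatter, or a modest one in either direction, seems most plausible.

Compound 4 is therefore expected to give about 3000 nM in this assay, within a range of 600 nM to 15000 nM. This estimate corresponds to an expected step of a 1.5-fold lower number from compound 3 to compound 4 (0.17 log units; within the scatter).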

Compound 4, half-maximal inhibitory concentration: 8950 nM
Beside the measured number, compound 4's estimate is 3.0-fold (0.47 log units) below it; the range from low to high includes it.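

At this aromatic carbon, methylamino in place of methoxy adds a hydrogen-bond donor, yet this assay shows only a 2.0-fold higher number from compound 3 to compound 4 (0.30 log units; within the scatter), so the assay does not separate these two groups. With the 1-benzofuran-2-yl group kept, removing one methyl from the nitrogen gives an at least 2.2-fold lower number from compound 2 to compound 4 (0.34 log units; beyond the scatter), and with methylamino kept, 1-benzofuran-2-yl in place of iodo gives an at least 2.2-fold lower number from compound 1 to compound 4 (0.34 log units; beyond the scatter), so a single change at either of these two places is enough to bring a compound from the limit to a measured number. Both of these sizes are only bounds, and the true steps could be larger: the limit of > 20000 nM in this assay, at which 2 of the 4 values shown sit.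

The compounds shown leave open how a free amino group, an ethoxy group or a longer chain such as butylamino would behave at this same carbon. They also leave open whether 1-benzofuran-2-yl in place of iodo would give a similar step with methoxy rather than methylamino on the core.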